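From a cyclohexyl ring to an open amine chain

This account rests on a few compounds, and the source may have more. Where it says the series, first, only, none or still open, it means among the compounds named here.

In an ADME assay on the whole organism (strain FVB) for pharmacokinetics, with Mus musculus as the target, read by LC-MS, at a dose of 30 mg/kg by the oral route (on this read-out lower numbers stand for lower exposure and higher numbers for higher exposure at the dose given), compound 3 `N[C@H]1CC[C@@H](Oc2ccc([C@H]3CC[C@]4(CC3)OOC3(O4)C4CC5CC(C4)CC3C5)cc2)CC1` gives 13400 ng.h/mL, level with compound 1 `CC(C)(O)CNCCCOc1ccc([C@H]2CC[C@]3(CC2)OOC2(O3)C3CC4CC(C3)CC2C4)cc1` at 11100 ng.h/mL and compound 2 `CC(C)(O)CN1CCC(Oc2ccc([C@H]3CC[C@]4(CC3)OOC3(O4)C4CC5CC(C4)CC3C5)cc2)CC1` at 14200 ng.h/mL, all within the scatter of one another. Compound 4 `NCCCCOc1ccc([C@H]2CC[C@]3(CC2)OOC2(O3)C3CC4CC(C3)CC2C4)cc1` carries 4-aminobutyl in place of 4-aminocyclohexyl on an oxygen on an aromatic ring. The steps measured at this same place are small: a 1.2-fold higher number from compound 1 to compound 3 (0.08 log units; within the scatter), a 1.3-fold higher number from compound 1 to compound 2 (0.11 log units; within the scatter) and a 1.1-fold lower number from compound 2 to compound 3 (0.03 log units; within the scatter), each within the scatter. For the measured compounds named here, the first of these also joins an open chain and the 4-aminocyclohexyl group, though no measured compound carries 4-aminobutyl itself. No step beyond the scatter is therefore expected in this assay, and the expected step is a 1.3-fold lower number from compound 3 to compound 4 (0.11 log units; within the scatter). The estimated value for compound 4 is 10500 ng.h/mL, with an expected range from 4500 ng.h/mL to 23000 ng.h/mL.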

Compound 4, area under the concentration-time curve: 4700 ng.h/mL
Beside the measured number, compound 4's estimate is 2.2-fold (0.35 log units) above it, and the stated range covers the measured number.
By their numbers in this assay, from the lowest: compound 4; then compounds 1, 3 and 2 (each within the scatter of the next).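

In this assay, this position turns out not to be indifferent to change: replacing 4-aminocyclohexyl with 4-aminobutyl gives a modest drop (a 2.9-fold lower number from compound 3 to compound 4 (0.46 log units; beyond the scatter)), and the piperidine-bearing compound shows one of similar size (a 3.0-fold lower number from compound 2 to compound 4 (0.48 log units; beyond the scatter)). Having no ring on this oxygen cannot alone separate the compounds, since compound 1 also lacks one there, yet what ends the chain still matters (a 2.4-fold lower number from compound 1 to compound 4 (0.37 log units; beyond the scatter)). Nothing available explains these drops.

From the compounds shown here alone, it remains open whether a longer chain such as 5-aminopentyl, or a dimethylamino group at the chain end, would stay with compound 4 or match compound 1.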